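Butyl in place of tert-butyl at compound 3

The source may hold more compounds than are shown below. What is called first, only, known or untested is meant among the compounds shown, and "the series" means these compounds.

In an ADME assay on Caco-2 cells (Homo sapiens) for permeability, read by LC-MS, in the apical to basolateral direction, with a stated time of 60 min, at pH 6.5 (on this read-out higher numbers stand for higher permeability and lower numbers for lower permeability), compound 1 `O=C(NCc1cc(Cl)ccc1-n1cnnn1)[C@@H]1C[C@H]2C[C@H]2N1C(=O)[C@H](O)c1ccccc1` gives 17 10^-6 cm/s and compound 2 `CC(C)(C)[C@@H](O)C(=O)N1[C@@H]2C[C@@H]2C[C@H]1C(=O)NCc1cc(Cl)ccc1-n1cnnn1` gives 34 10^-6 cm/s and the two lie within the scatter of each other. Compound 3 `CCCC[C@@H](O)C(=O)N1[C@@H]2C[C@@H]2C[C@H]1C(=O)NCc1cc(Cl)ccc1-n1cnnn1` carries butyl in place of tert-butyl on a saturated chain carbon bound to a carbonyl carbon and an oxygen on a saturated carbon with butyl in place of tert-butyl on a saturated chain carbon bound to a carbonyl carbon and an oxygen on a saturated carbon. Within the data shown here, the only measured step at this place is a 2.0-fold higher number from compound 1 to compound 2 (0.30 log units; within the scatter) and it exchanges phenyl for tert-butyl. No step beyond the scatter is therefore expected in this assay for this change. The expected step is a 1.2-fold lower number from compound 2 to compound 3 (0.08 log units; within the scatter) on this estimate. Compound 3 is estimated at 28 10^-6 cm/s (14 10^-6 cm/s to 55 10^-6 cm/s).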

Compound 3, apparent permeability: 35 10^-6 cm/s
The estimate for compound 3 lay 1.3-fold (0.10 log units) below the measured number, within the range that was stated.
By their numbers in this assay, from the lowest: compounds 1, 2 and 3 (each within the scatter of the next, the first and the last beyond it).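

In this assay the change from tert-butyl to butyl on this saturated chain carbon gives a 1.0-fold higher number from compound 2 to compound 3 (0.01 log units; within the scatter) and so leaves the number unmoved within the scatter, even though the two groups have the same heavy-atom count. Among these compounds, replacing phenyl with butyl gives a 2.1-fold higher number from compound 1 to compound 3 (0.31 log units; beyond the scatter) as the first modest step beyond the scatter at this place, whereas tert-butyl for phenyl stayed within it. No evidence on hand bears on these steps.

Still open, from the compounds shown here alone, is how a longer chain, an amine or a carboxylic acid at this place would read in this assay on the shared core.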